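The source may hold more compounds than are shown below. What is called first, only, known or untested is meant among the compounds shown, and "the series" means these compounds.

Among the compounds with values here, in an assay on isolated protein for inhibition of Leucine-rich repeat serine/threonine-protein kinase 2 variant G2019S (Homo sapiens), read by TR-FRET and LanthaScreen, with stated times of 50 min and 30 min, in the presence of a further agent that is not named here (a lower number here means a stronger inhibitor, a higher number a weaker inhibitor), compound 2 `C[C@@H]1CCCN1c1c(C#N)c2c(N)nc(Nc3cn[nH]c3)nc2n1C` gives 6 nM and compound 1 `Cc1c(Nc2nc(N)c3c(C#N)c(N4CCC[C@H]4C)n(C)c3n2)cnn1C` gives 43 nM; the one counted step, a 7.2-fold lower number from compound 1 to compound 2 (0.86 log units; beyond the scatter), concerns a group that compound 3 does not carry. Compound 3 `Cn1c(N2CCCC2)c(C#N)c2c(N)ncnc21`, which lacks that side group altogether, gives 1910 nM, the highest of the three numbers, far beyond the scatter from both compound 1 and compound 2. Compound 4 `Cn1c(N)c(C#N)c2c(N)ncnc21` differs from compound 3 in one place: amino in place of pyrrolidin-1-yl on an aromatic carbon. Within the data shown here, no measured step touches this position, so nothing shows how it behaves; the only guide is that compound 3 already sits at the weak end. The change is therefore expected to keep the number high or raise it further. Compound 4 is estimated at 5000 nM, in a range from 1500 nM to 20000 nM. The expected step is a 2.6-fold higher number from compound 3 to compound 4 (0.42 log units; beyond the scatter).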

Compound 4, half-maximal inhibitory concentration: 8560 nM
Compound 4: middle estimate off by 1.7-fold (0.23 log units), on the low side, and the stated range covers the measured number.
By their numbers in this assay, from the lowest: compound 2; then compound 1; then compound 3; then compound 4.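

Amino in place of pyrrolidin-1-yl gives a 4.5-fold higher number from compound 3 to compound 4 (0.65 log units; beyond the scatter) and is the first measured change at this position, next to the ring nitrogen. The position therefore responds to the change: the group with one heavy atom gives a weaker inhibitor than the five-atom ring, though the step is modest. No evidence here accounts for the rise.

Going by these compounds, whether dimethylamino or piperidin-1-yl would give a number nearer compound 3 or compound 4 stays open. So does whether the same swap would act alike in compound 2, which carries a 1H-pyrazol-4-yl group.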